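The source may report more compounds than this note shows. Statements on the series, on what has been measured and on what is new or still open speak of the compounds shown alone.

Measured compounds, each with its result in a functional assay on HCT-116 cells (Homo sapiens) for inhibition, read by MTT assay, with a stated time of 48 h; a lower number here means a stronger inhibitor, a higher number a weaker inhibitor:

Compound 1 `COc1ccc(-n2c(SCC(=O)C3CC3)nnc2-c2cc(OC)c(OC)c(OC)c2)cc1` gives > 60000 nM.
Compound 2 `CCOC(=O)CSc1nnc(-c2cc(OC)c(OC)c(OC)c2)n1-c1ccc(OC)cc1` gives > 60000 nM.
Compound 3 `COc1cc(-c2nnc(SCC(=O)C3CC3)n2-c2ccc(N(C)C)cc2)cc(OC)c1OC` gives > 60000 nM.

Each of these three results is a limit of the assay, not a number. The value for compound 1 is a limit. The value for compound 2 is a limit. The value for compound 3 is a limit. All three sit at the limit of > 60000 nM in this assay, at which 3 of the 3 values shown sit, so none of the steps between them can be read.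

Compound 2 differs from compound 1 by ethoxy in place of cyclopropyl on a carbonyl carbon. The step that the two limits leave unreadable from compound 1 to compound 2 cannot be sized, since both ends are limits. Compound 3 differs from compound 1 by dimethylamino in place of methoxy on an aromatic carbon, and the step that the two limits leave unreadable from compound 1 to compound 3 is likewise unreadable.

Compound 4 `CCOC(=O)CSc1nnc(-c2cc(OC)c(OC)c(OC)c2)n1-c1ccc(N(C)C)cc1` has not yet been measured in this assay. It differs from compound 3 by ethoxy in place of cyclopropyl on a carbonyl carbon. For the measured compounds named here, this is the same change as the one from compound 1 to compound 2, made at the same place, and the two cores differ by the change described for compound 3 against compound 1.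

Since the measured step of this change is not readable, the expectation for compound 4 rests only on the finding that all three measured values sit at the limit of > 60000 nM in this assay, at which 3 of the 3 values shown sit. Compound 4 is therefore expected to give a limit as well, with an estimated step that the limit leaves unreadable from compound 3 to compound 4 and an estimated value of 100000 nM, between 30000 nM and 400000 nM.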

Compound 4, half-maximal inhibitory concentration: > 60000 nM
Compound 4 ended at the assay's limit; the forecaster's own chance of this, stated with the estimate: 90%; the middle value is on the limit's open side.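

In this assay compound 4 gives > 60000 nM, which is a limit of the assay and not a number. Neither step into compound 4, from compound 2 or from compound 3, can be read, since every result shown is a limit: the limit of > 60000 nM in this assay, at which 4 of the 4 values shown sit.

The compounds shown leave open whether ethoxy in place of cyclopropyl on a carbonyl carbon, or dimethylamino in place of methoxy on an aromatic carbon, changes inhibition at all.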